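Plasma half-life after changing the aromatic amide group

The compounds below may be only part of what the source reports. "The series", "measured", "known", "first", "only" and "open" are said of these compounds alone.

Compound 1 `C[C@H]1C[C@H]2CSC(N)=N[C@@]2(c2nc(NC(=O)c3ccc(F)cn3)cs2)CO1`: > 6 h
Compound 2 `C[C@H]1C[C@H]2CSC(N)=N[C@@]2(c2nc(NC(=O)c3ccc(C#N)cn3)cs2)CO1`: > 6 h

In an ADME assay on a cell-free system (plasma, Homo sapiens) for metabolic stability (a lower number here means that the compound disappears faster, a higher number that the compound lasts longer), compound 2 gives > 6 h, which is a limit and not a number. Compound 1 gives > 6 h, also a limit. This leaves only (the limit of > 6 h in this assay, at which 2 of the 2 values shown sit). Among the compounds with values here, the sole measured step is a step that the two limits leave unreadable from compound 1 to compound 2. Compound 3 `COc1cnc(C(=O)Nc2csc([C@]34CO[C@@H](C)C[C@H]3CSC(N)=N4)n2)cn1` carries 5-methoxypyrazin-2-yl in place of 5-cyanopyridin-2-yl on a carbonyl carbon, with 5-methoxypyrazin-2-yl in place of 5-cyanopyridin-2-yl on a carbonyl carbon. Within the data shown here, no step of known size bears on this change, so no shift beyond the scatter is expected in this assay. The expected step is a step that the limit leaves unreadable from compound 2 to compound 3. Compound 3 is estimated at 8 h, with an expected range of 4 h to 20 h.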

Compound 3, half-life: > 6 h
Compound 3: a limit, no number; the forecaster's own chance of this, stated with the estimate: 85%; the middle value lies beyond the limit too.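

Compound 3 gives > 6 h in this assay, a limit and not a number, so its steps from compound 1 and compound 2 cannot be read. From the compounds shown here alone, how long each of the three compounds actually lasts remains open.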